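Pyridine-to-N-oxide change in a benzylidene oxindole series

A few compounds are considered here, and "the series" means these few. Any claim that something is new, unique, unknown or untested is made for them only; others in the source may bear on it.

The measured compounds:
compound 1 `O=C1/C(=C\c2ccncc2)c2ccccc2N1Cc1ccccc1` with 24.4%
compound 2 `O=C1/C(=C\c2cccnc2)c2ccccc2N1Cc1ccccc1` with 75.9%

Compound 2 stands highest of the two numbers in a functional assay on HL-60 cells (Homo sapiens) for cytotoxicity, read by MTT assay, with a stated time of 72 h, tested at 2.5 uM; on this read-out lower numbers stand for a stronger effect and higher numbers for a weaker effect at the one concentration tested; the nearest is compound 1, and the step of a number 51.5 percentage points higher from compound 1 to compound 2 (beyond the scatter) lies beyond the scatter. Compound 3 `O=C1/C(=C\c2cc[n+]([O-])cc2)c2ccccc2N1Cc1ccccc1` differs from compound 2 by a group of 7 heavy atoms (5 carbon, 1 nitrogen, 1 oxygen; one six-membered aromatic ring with 1 hetero atom) in place of a group of 6 heavy atoms (5 carbon, 1 nitrogen; one six-membered aromatic ring with 1 hetero atom), on a double-bonded chain carbon bound to a double-bonded ring carbon. Within the data shown here, only one measured step bears on this change, the large one from compound 1 to compound 2, which shows that the ring attached at this position moves the read-out strongly. The group entering in compound 3 carries its nitrogen and oxygen in the arrangement of compound 1's ring rather than compound 2's, so a step downward, in the direction of compound 1, is expected, but its size is uncertain. Compound 3 is expected to give 45%, within 20% to 80%, a step of a number 30.9 percentage points lower from compound 2 to compound 3 (beyond the scatter).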

Compound 3, a percentage reported as activity, at one concentration (the size of the read-out at that concentration, not a potency): 43.4%
Estimate against measurement, compound 3: 1.6 percentage points above; the range from low to high includes it.
By their numbers in this assay, from the lowest: compound 1; then compound 3; then compound 2.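

In this assay, the group on the double-bonded chain carbon bound to a double-bonded ring carbon proves to be more than a choice between the two pyridine rings: the oxygen-bearing ring of compound 3 gives a stronger effect than pyridin-3-yl, with a number 32.5 percentage points lower from compound 2 to compound 3 (beyond the scatter), yet a weaker one than pyridin-4-yl, with a number 19 percentage points higher from compound 1 to compound 3 (beyond the scatter). Adding oxygen to the ring nitrogen of compound 1 therefore gives up part of its effect at this concentration, but the larger share remains. No evidence is available on what lies behind either step.

The compounds shown leave open how a phenyl ring, a pyridin-2-yl ring or a ring bearing an amine or a carboxylic acid would read at this place. They also leave open whether an oxygen on the ring nitrogen of compound 2 would move the read-out in the same way.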